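Swapping an allyl for a methoxyethyl chain on a xanthine core

The compounds below may be only part of what the source reports. "The series", "measured", "known", "first", "only" and "open" are said of these compounds alone.

Of the compounds shown here, two from this series have so far been tested in an assay on HEK293 cells for displacement of a labelled ligand from adenosine receptor A2b (Homo sapiens); on this read-out lower numbers stand for stronger inhibition and higher numbers for weaker inhibition. Compound 1 `C#CCn1c(=O)c2[nH]c(Cc3cccs3)nc2n(Cc2ccco2)c1=O` gives 269 nM in this assay. Compound 2 `C=CCn1c(=O)c2c(nc(Cc3c(F)cccc3F)n2C)n(Cc2ccco2)c1=O` gives 21.4 nM in this assay, the lowest of the two numbers; compound 1 lies a considerable distance higher, well beyond the scatter of repeated measurements. Compound 2 and compound 1 differ in several places at once, so no single change can be read from their gap.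

Compound 3 `COCCn1c(=O)c2c(nc(Cc3c(F)cccc3F)n2C)n(Cc2ccco2)c1=O` is not yet measured. It differs from compound 2 in one place: methoxymethyl in place of vinyl on a saturated chain carbon bound to an aromatic nitrogen. Within the data shown here, no pair of measured compounds shows this change on its own, so there is nothing to calibrate it against. The chain keeps roughly its length, trades a double bond for an ether oxygen, and sits away from the parts that change between compound 1 and compound 2. The step from compound 2 to compound 3 is expected to be small, close to or just beyond the scatter, most likely towards a slightly higher number, a 1.9-fold higher number from compound 2 to compound 3 (0.27 log units; within the scatter). Compound 3 is therefore estimated to give 40 nM in this assay, with a plausible range from 12 nM to 150 nM.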

Compound 3, inhibition constant: 38.9 nM
Beside the measured number, compound 3's estimate is 1.0-fold (0.01 log units) above it; the measured number falls inside the stated range.
By their numbers in this assay, from the lowest: compounds 2 and 3 (each within the scatter of the next); then compound 1.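

Among these compounds, this is the first step that changes one place only, so it can be read on its own. In this assay, putting methoxymethyl in place of vinyl on a saturated chain carbon bound to an aromatic nitrogen gives a 1.8-fold higher number from compound 2 to compound 3 (0.26 log units; within the scatter), which means that compound 2 and compound 3 cannot be told apart on this read-out, even though a double bond has left the chain and an ether oxygen, counted as a hydrogen-bond acceptor, has entered it. No measurement of any property of these two groups is available here, so the data show only that the two chains read alike and offer no explanation for it.

Still open, going by these compounds, is how much further this chain can be altered: a longer ether chain, an amine or a carboxylic acid at its end might stay within the scatter of compound 2 or might move well away from it. Also open, on these data alone, is whether the same swap would read alike in a compound with the other parts of compound 1, as the step is known only with the remaining groups of compound 2.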